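A few compounds are considered here, and "the series" means these few. Any claim that something is new, unique, unknown or untested is made for them only; others in the source may bear on it.

Compound 1 `COc1cc(C(=N)N)ccc1-c1cc2ccc(C(=N)N)cc2o1` was examined in an ADME assay on L6 cells (Rattus norvegicus) for cytotoxicity (a lower number here means a stronger inhibitor, a higher number a weaker inhibitor), and in this assay compound 1 gives 108000 nM. Compound 3 `N=C(N)c1ccc(-c2cc3ccc(C(=N)N)cc3o2)c(O)c1` differs from compound 1 only by hydrogen in place of methyl on an oxygen on an aromatic ring. In this assay compound 3 reaches only a limit of the assay, > 221000 nM, and no number. The measured change is accordingly an at least 2.0-fold higher number from compound 1 to compound 3 (0.31 log units; beyond the scatter), a step that is itself only a lower bound.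

Compound 2 `COc1cc(C(=N)NC(C)C)ccc1-c1cc2ccc(C(=N)NC(C)C)cc2o1` belongs to a second core; how the core of compound 2 differs from the core of compound 1 is not broken down here. In this assay compound 2 likewise reaches only a limit of the assay, > 181000 nM, and no number. Compound 4 `CC(C)NC(=N)c1ccc(-c2cc3ccc(C(=N)NC(C)C)cc3o2)c(O)c1` has not yet been measured. It differs from compound 2 by hydrogen in place of methyl on an oxygen on an aromatic ring, which is the same change as that from compound 1 to compound 3, at a place described in identical words.

Compound 4 is therefore expected to sit no lower than compound 2 in this assay, because compound 2 already stands at the limit of > 181000 nM in this assay, at which 1 of the 3 values shown sits, and because the matching change in the first core gave an at least 2.0-fold higher number from compound 1 to compound 3 (0.31 log units; beyond the scatter). The step from compound 2 to compound 4 is estimated as a step that the limit leaves unreadable from compound 2 to compound 4. Compound 4 is expected to give about 300000 nM in this assay, most plausibly between 150000 nM and 700000 nM, and most probably reported only as a limit rather than a number.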

Compound 4, half-maximal inhibitory concentration: > 183000 nM
Compound 4: a limit, no number; the forecaster's own chance of this, stated with the estimate: 85%; the middle value lies beyond the limit too.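

In this assay compound 4 gives only a limit, > 183000 nM, and no number. Compound 2 also gives only a limit, > 181000 nM. Among these compounds, with a limit on both sides, no step from compound 2 to compound 4 can be read. The compounds shown leave open how large the change from methoxy to hydroxy is in the core of compound 2, and whether it matches the change from compound 1 to compound 3.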